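This account rests on a few compounds, and the source may have more. Where it says the series, first, only, none or still open, it means among the compounds named here.

Measured in a functional assay on the whole organism with Mus musculus as the target; on this read-out lower numbers stand for an effect already at smaller amounts and higher numbers for an effect only at larger amounts of compound:

Compound 1 `CC[C@H](NCc1ccc(OCc2ccccc2)cc1)C(N)=O`: 119 mg/kg
Compound 2 `CNC(=O)[C@@H](CO)NCc1ccc(OCc2cccc(C)c2)cc1`: 41.3 mg/kg
Compound 3 `CNC(=O)[C@@H](CO)NCc1ccc(OCc2cccc(C(F)(F)F)c2)cc1`: 19.5 mg/kg

Among these three, compound 3 has the lowest number, at 19.5 mg/kg, and both other compounds lie beyond the scatter from it. The next compound, compound 4 `CNC(=O)[C@@H](CO)NCc1ccc(OCc2cccc(F)c2)cc1`, keeps the shared core of compound 3 and carries fluoro in place of trifluoromethyl on an aromatic carbon.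

Going by the values given here, only one measured step bears on this change, since compound 1 differs from the others in more than one place. That step is a 2.1-fold lower number from compound 2 to compound 3 (0.33 log units; beyond the scatter), and it is modest. Among the compounds with values here, no measured compound carries fluoro at this place, so the step gives only a rough guide to size. In this assay, a similarly modest move is therefore expected, towards a higher number. The expected step is a 1.4-fold higher number from compound 3 to compound 4 (0.16 log units; within the scatter). For compound 4 the estimated value is 28 mg/kg, with an expected range of 12 mg/kg to 60 mg/kg.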

Compound 4, dose for half-maximal effect: 25.1 mg/kg
Beside the measured number, compound 4's estimate is 1.1-fold (0.05 log units) above it, within the range that was stated.
By their numbers in this assay, from the lowest: compounds 3, 4 and 2 (each within the scatter of the next, the first and the last beyond it); then compound 1.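

Fluoro in place of trifluoromethyl gives a 1.3-fold higher number from compound 3 to compound 4 (0.11 log units; within the scatter) in this assay and fluoro in place of methyl gives a 1.6-fold lower number from compound 2 to compound 4 (0.22 log units; within the scatter) on the same read-out. At this place on the aromatic ring, fluoro therefore cannot be told apart from either of the other two groups, even though those two stand apart, with a 2.1-fold lower number from compound 2 to compound 3 (0.33 log units; beyond the scatter) between them. Nothing measured here offers an explanation for these numbers.

Going by these compounds, whether chloro, methoxy, an amine or a carboxylic acid at this place would stand apart from these three groups remains open. Also open, on these data alone, is how fluoro would read on the core of compound 1, which differs from the other compounds in more than one place.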